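Ethoxy in place of methyl on compound 2

The source may hold more compounds than are shown below. What is called first, only, known or untested is meant among the compounds shown, and "the series" means these compounds.

In a functional assay on HeLa cells (Homo sapiens) for antiproliferative activity, read by MTT assay, with a stated time of 72 h (on this read-out lower numbers stand for stronger inhibition and higher numbers for weaker inhibition), compound 1 (`CCOc1ccc(Nc2c(C(=O)c3cc(OC)c(OC)c(OC)c3)sc3ccccc23)cc1`) gives 700 nM and compound 2 (`COc1cc(C(=O)c2sc3cc(C)ccc3c2Nc2ccc(C)cc2)cc(OC)c1OC`) gives 980 nM, so compound 2 stands within the scatter of compound 1 . Compound 3 (`CCOc1ccc(Nc2c(C(=O)c3cc(OC)c(OC)c(OC)c3)sc3cc(C)ccc23)cc1`) has ethoxy in place of methyl on an aromatic carbon of compound 2, para to a large group: ethoxy in place of methyl on an aromatic carbon. Within the data shown here, no measured step isolates this change. With compound 2 at 980 nM as the starting point, no step beyond the scatter is expected in this assay, in either direction. The estimated change is a 1.3-fold lower number from compound 2 to compound 3 (0.12 log units; within the scatter). For compound 3 the expected value is 750 nM, with an estimated range of 300 nM to 1800 nM.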

Compound 3, half-maximal inhibitory concentration: 4300 nM
For compound 3 the middle estimate is 5.7-fold (0.76 log units) below the measured one, outside the stated range (above it).
By their numbers in this assay, from the lowest: compounds 1 and 2 (each within the scatter of the next); then compound 3.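

In this assay ethoxy in place of methyl on the aromatic carbon is not a neutral swap when the core carries its methyl, giving a 4.4-fold higher number from compound 2 to compound 3 (0.64 log units; beyond the scatter). With the ethoxy held fixed, methyl in place of hydrogen on the core also costs activity, giving a 6.1-fold higher number from compound 1 to compound 3 (0.79 log units; beyond the scatter), so the two groups together give the highest number of the three. Nothing available explains these steps.

Open, from the compounds shown here alone, is whether methoxy or an amine in place of the ethoxy would stay near compound 2. Also open, going by these compounds, is whether a longer chain would move the number further.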